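A few compounds are considered here, and "the series" means these few. Any claim that something is new, unique, unknown or untested is made for them only; others in the source may bear on it.

Compound 2 `COc1ccc(C2C(C#N)=C(N)OC(c3c[nH]c4ccccc34)=C2C#N)cc1` sits on a shared core with compound 1 `Cc1ccccc1C1C(C#N)=C(N)OC(c2c[nH]c3ccccc23)=C1C#N`, the two differing only in the aryl group on a saturated ring carbon. For the measured compounds named here, in a functional assay, tested at 200 ug/mL (on this read-out lower numbers stand for a weaker effect and higher numbers for a stronger effect at the one concentration tested), compound 1 gives 21.4%, and in this assay compound 2 gives 26.4%, so the two numbers lie within the scatter of each other; the change a number 5 percentage points higher from compound 1 to compound 2 (within the scatter) is the only measured step on this position. Compound 3 `N#CC1=C(N)OC(c2c[nH]c3ccccc23)=C(C#N)C1c1ccccc1Cl` takes the same position one step further: 2-chlorophenyl in place of 4-methoxyphenyl on a saturated ring carbon. Going by the values given here, the only step that bears on it, the swap of one aryl group for another on that carbon in this assay, stayed within the scatter, so a step of the same kind, from compound 2 to compound 3, is expected to show no shift beyond the scatter, with the estimated step of a number 2.4 percentage points lower from compound 2 to compound 3 (within the scatter). Compound 3 in this assay is therefore expected to give about 24%, between 12% and 36%.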

Compound 3, a percentage reported as activity, at one concentration (the size of the read-out at that concentration, not a potency): 14.5%
Compound 3: middle estimate off by 9.5 percentage points, on the high side; low and high end bracket the measured number.
By their numbers in this assay, from the lowest: compounds 3, 1 and 2 (each within the scatter of the next, the first and the last beyond it).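

In this assay, the aryl group on the saturated ring carbon now proves able to move the read-out: a number 11.9 percentage points lower from compound 2 to compound 3 (beyond the scatter), a modest step and the first on this position beyond the scatter. For the compounds shown here, the swap of chloro for methyl on an aromatic carbon does not do so, at a number 6.9 percentage points lower from compound 1 to compound 3 (within the scatter), which leaves 2-chlorophenyl and 2-methylphenyl unresolved, so the one step beyond the scatter rests on a single pair of compounds. No measurement at hand accounts for this difference.

Since 2-chlorophenyl and 4-methoxyphenyl differ both in the group and in where it sits on the aromatic ring, the compounds shown do not separate those two changes. Also open, going by these compounds, is how this position responds to an unsubstituted phenyl, or to an aryl group carrying an amine or a carboxylic acid.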